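This account rests on a few compounds, and the source may have more. Where it says the series, first, only, none or still open, it means among the compounds named here.

Going by the values given here, in a functional assay on cells (Homo sapiens) for antiproliferative activity, read by MTT assay, with a stated time of 48 h (on this read-out higher numbers stand for weaker inhibition and lower numbers for stronger inhibition), compound 1 `CCN(CC)CCn1c(N)c(-c2nc3ccccc3[nH]2)c2nc(C#N)c(C#N)nc21` gives 25400 nM, the higher of the two numbers measured so far, and compound 2 `CN1CCN(CCn2c(N)c(-c3nc4ccccc4[nH]3)c3nc(C#N)c(C#N)nc32)CC1` gives 9110 nM. Compound 3 `CN(C)CCCn1c(N)c(-c2nc3ccccc3[nH]2)c2nc(C#N)c(C#N)nc21` differs from compound 1 by (dimethylamino)methyl in place of diethylamino on a saturated chain carbon, two bonds along the chain from an aromatic nitrogen. Among the compounds with values here, one measured step bears on this change, at the same place but with another group: a 2.8-fold lower number from compound 1 to compound 2 (0.45 log units; beyond the scatter). A smaller shift in the same direction is expected, giving an estimated 1.5-fold lower number from compound 1 to compound 3 (0.17 log units; within the scatter). Compound 3 is estimated at 17000 nM, with an expected range of 7000 nM to 40000 nM.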

Compound 3, half-maximal inhibitory concentration: 1820 nM
Beside the measured number, compound 3's estimate is 9.3-fold (0.97 log units) above it; measured number outside the range, below it.
By their numbers in this assay, from the lowest: compound 3; then compound 2; then compound 1.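

In this assay the end of the chain on the aromatic nitrogen proves able to move the number much further than the earlier step showed: 3-(dimethylamino)propyl in place of 2-(diethylamino)ethyl brings a 14-fold lower number from compound 1 to compound 3 (1.14 log units; beyond the scatter) for this change. Against the 4-methylpiperazin-1-yl chain the same group brings a 5.0-fold lower number from compound 2 to compound 3 (0.70 log units; beyond the scatter) as well, so compound 3 has the lowest number of the three. Nothing measured here explains this gain.

The compounds shown leave open whether it follows the longer chain or the dimethylamino group. 2-(Dimethylamino)ethyl would separate the two, and 3-(diethylamino)propyl would test the same question from the other side.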